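This account rests on a few compounds, and the source may have more. Where it says the series, first, only, none or still open, it means among the compounds named here.

Working notes on the series. Three members carrying the shared core have been measured: compound 1 `COc1ccc(CN(C(=O)Nc2ccc(Cl)c(C(F)(F)F)c2)n2cnnc2)cc1OC`, compound 2 `O=C(Nc1ccccc1)N(Cc1ccccn1)n1cnnc1` and compound 3 `Cc1ccsc1CN(C(=O)Nc1cccc(C#N)c1)n1cnnc1`. All three were run in a functional assay on MDA-MB-231 cells (Homo sapiens) for cytotoxicity, read by MTT assay, with a stated time of 48 h; a higher number here means a weaker inhibitor, a lower number a stronger inhibitor. In this assay compound 1 returns only a limit, > 50000 nM. Compound 2 likewise gives only a limit, > 50000 nM. Compound 3 also reaches no number but a limit, > 50000 nM. Every value gathered so far thus sits in the same place: the limit of > 50000 nM in this assay, at which 3 of the 3 values shown sit. Where compound 3 stands relative to the other two cannot be read off, since none of the three has a number, and no step between measured compounds is available.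

Compound 4 `Cc1ccsc1CN(C(=O)Nc1ccccc1)n1cnnc1` is the next member and has not yet been tested in this assay. Its difference from compound 3 is hydrogen in place of cyano on an aromatic carbon; cut one bond further out, the change reads 3-cyanophenyl to phenyl.

With nothing but limits in hand, no step beyond the scatter is expected in this assay; the change from a cyano to a hydrogen is expected to leave compound 4 at the limit as well. The estimate for compound 4 in this assay is 60000 nM, expected between 30000 nM and 150000 nM. That estimate corresponds to an expected step that the limit leaves unreadable from compound 3 to compound 4, within the scatter.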

Compound 4, half-maximal inhibitory concentration: > 50000 nM
Compound 4 ended at the assay's limit (the forecaster's own chance of this, stated with the estimate: 85%); the middle value is on the limit's open side.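

No step can be read from compound 3 to compound 4 or from compound 2 to compound 4, as every value shown sits at one place: the limit of > 50000 nM in this assay, at which 4 of the 4 values shown sit.

The compounds shown leave open whether any member of the series reaches a measurable value in this assay, and whether replacing cyano with hydrogen changes that value at all.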